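Aryl sulfonamide hydroxamates: trifluoromethyl for trifluoromethoxy

This account rests on a few compounds, and the source may have more. Where it says the series, first, only, none or still open, it means among the compounds named here.

Compound 1 `O=C(NO)c1cnc(N2CCN(S(=O)(=O)c3ccc(OC(F)(F)F)cc3)CC2)s1` carries a hydroxamic acid on the shared core and a trifluoromethoxy-bearing aryl sulfonyl group; in a functional assay on MCF7 cells (Homo sapiens) for antiproliferative activity (a lower number here means a stronger inhibitor of growth, a higher number a weaker inhibitor of growth), compound 1 gives 4000 nM. Compound 2 `CC(=O)N1CCN(c2ncc(C(=O)NO)s2)CC1` has an acetyl in place of the aryl sulfonyl. In this assay compound 2 gives only > 100000 nM, which is a limit of the assay and not a number, namely (the limit of > 100000 nM in this assay, at which 1 of the 3 values shown sits). Compound 3 `O=C(/C=C/c1cnc(N2CCN(S(=O)(=O)c3ccc(OC(F)(F)F)cc3)CC2)s1)NO` carries the 2-(hydroxycarbamoyl)ethenyl group; in this assay compound 3 gives 6000 nM. The step of a 1.5-fold higher number from compound 1 to compound 3 (0.18 log units; within the scatter) is within the scatter, so of the two numbers measured compound 3 stands at the upper one without being separable from compound 1, and compound 2 stands apart only as a limit.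

Compound 4 `O=C(/C=C/c1cnc(N2CCN(S(=O)(=O)c3ccc(C(F)(F)F)cc3)CC2)s1)NO` differs from compound 3 by trifluoromethyl in place of trifluoromethoxy on an aromatic carbon. For the measured compounds named here, no measured step touches this group: the only measured step, a 1.5-fold higher number from compound 1 to compound 3 (0.18 log units; within the scatter), concerns the hydroxamate side, and compound 2 speaks to the whole aryl sulfonyl, not to its substituent. The change is therefore expected to amount to no change at the digits printed from compound 3 to compound 4 (within the scatter), which is no step beyond the scatter. Compound 4 is expected to give 6000 nM, with a range from 2000 nM to 18000 nM.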

Compound 4, concentration for 50% growth inhibition: 3000 nM
Compound 4: the middle estimate sits 2.0-fold (0.30 log units) above what was measured, within the range that was stated.
By their numbers in this assay, from the lowest: compounds 4, 1 and 3 (each within the scatter of the next). At a limit, above all of these: compound 2.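

At the aromatic carbon para to a large group, the series now has its first reading in this assay of a change within the aryl sulfonyl rather than of the whole group: a 2.0-fold lower number from compound 3 to compound 4 (0.30 log units; within the scatter), for trifluoromethyl in place of trifluoromethoxy. The earlier compounds shown here spoke only to the hydroxamate side and to the aryl sulfonyl as a whole; this pair shows that, with the 2-(hydroxycarbamoyl)ethenyl group in place, the oxygen of trifluoromethoxy can go without a step beyond the scatter, so the two fluorinated groups cannot be told apart at this position. Nothing measured in the series speaks to a cause for this reading.

Still open, as far as these compounds go, is whether the same exchange reads alike on the hydroxamic acid set directly on the core, as in compound 1, and whether any group at this carbon moves the number beyond the scatter. A plain hydrogen, a methoxy, a chlorine, an amine or a carboxylic acid at this carbon would test whether the position responds at all.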